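The source may report more compounds than this note shows. Statements on the series, on what has been measured and on what is new or still open speak of the compounds shown alone.

Compound 1, `C/C(=N\NC(=O)COc1cccc2ccccc12)c1ccccc1`: 105 ug/mL
Compound 2, `COc1cc(/C=N/NC(=O)COc2cccc3ccccc23)cc(OC)c1OC`: 13.4 ug/mL

Of the compounds shown here, two have been tested in an ADME assay on MT4 cells (Homo sapiens) for cytotoxicity, read by MTT assay, with a stated time of 4 days; on this read-out higher numbers stand for lower toxicity in this test and lower numbers for higher toxicity in this test. Compound 1 gives 105 ug/mL, the higher of the two numbers, while compound 2 gives 13.4 ug/mL; the gap between them lies beyond the usual scatter, so compound 1 is the less toxic of the pair in this assay. Compound 3, `C/C(=N\NC(=O)COc1cccc2ccccc12)c1ccc([N+](=O)[O-])cc1`, has not yet been measured. It differs from compound 1 in one place: nitro in place of hydrogen on an aromatic carbon, which in words is nitro in place of hydrogen on an aromatic carbon, the position being para to a large group. For the measured compounds named here, no measured pair shows what such a change does here, so the expectation rests on compound 1 alone. The step of a 1.3-fold lower number from compound 1 to compound 3 (0.12 log units; within the scatter) is expected to stay within the scatter, with at most a slight move toward a lower number. Compound 3 is therefore estimated at 80 ug/mL, with a range from 30 ug/mL to 200 ug/mL.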

Compound 3, half-maximal cytotoxic concentration: 89.3 ug/mL
Estimate against measurement, compound 3: 1.1-fold (0.05 log units) below; low and high end bracket the measured number.
By their numbers in this assay, from the lowest: compound 2; then compounds 3 and 1 (each within the scatter of the next).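

Nitro in place of hydrogen on an aromatic carbon, para to a large group, turns phenyl into 4-nitrophenyl, and in this assay this swap gives a 1.2-fold lower number from compound 1 to compound 3 (0.07 log units; within the scatter) as the first step read directly at this position. Compound 1 and compound 3 therefore cannot be told apart in this test, so this position of the core accepts nitro without a measurable difference in toxicity to these cells. No measurement at hand bears on the reason for this result.

Going by these compounds, a single group at a single position says little about other groups, so it remains open whether an amine or a carboxylic acid at this same position would also stay within the scatter. Also open, on these data alone, is whether nitro elsewhere on this ring would read the same way.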